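A few compounds are considered here, and "the series" means these few. Any claim that something is new, unique, unknown or untested is made for them only; others in the source may bear on it.

Of the compounds shown here, three sharing one core have been measured in a physicochemical assay for lipophilicity, read by HPLC, using the shake flask method; a lower number here means a more polar compound, a higher number a more lipophilic compound. Compound 1 `C/C(=N\C#N)N(Cc1ccc(Cl)nc1)C(C)C` gives 1.46. Compound 2 `CC(C)C/C(=N\C#N)N(C)Cc1ccc(Cl)nc1` gives 1.75. Compound 3 `C/C(=N\C#N)N(Cc1ccccc1)Cc1ccc(Cl)nc1` gives 2.11, the highest of the three; compound 2 stands nearer to it than compound 1 does, and both sit beyond the scatter below it. Within the data shown here, the only single change between two measured compounds is the one from compound 1 to compound 3, where benzyl in place of isopropyl on an amine nitrogen gave a number 0.65 log units higher from compound 1 to compound 3 (beyond the scatter).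

Compound 4 `CCN(Cc1ccc(Cl)nc1)/C(C)=N/C#N` has not yet been measured. It differs from compound 3 in one place: methyl in place of phenyl on a saturated chain carbon bound to an amine nitrogen. Read one bond further out, the same difference is benzyl to ethyl, so it runs in the opposite direction to the measured step from compound 1 to compound 3, with ethyl taking the place that isopropyl held there. On that basis the number for compound 4 is expected to fall by about as much as the benzyl added in the measured step, perhaps a little more. The step from compound 3 to compound 4 is estimated at a number 0.91 log units lower from compound 3 to compound 4 (beyond the scatter). Compound 4 is therefore expected to give 1.2, with a range from 0.8 to 1.6.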

Compound 4, partition coefficient: 1.19
Compound 4: middle estimate off by 0.01 log units, on the high side, and the stated range covers the measured number.
By their numbers in this assay, from the lowest: compounds 4, 1 and 2 (each within the scatter of the next, the first and the last beyond it); then compound 3.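

In this assay the change at this place, methyl in place of phenyl on a saturated chain carbon bound to an amine nitrogen, gave a clear step (a number 0.92 log units lower from compound 3 to compound 4 (beyond the scatter)), so compound 3 with its benzyl group now stands beyond the scatter from two compounds with different small groups at that nitrogen, isopropyl in compound 1 and ethyl in compound 4. Those two small groups cannot be told apart by this measurement (a number 0.27 log units lower from compound 1 to compound 4 (within the scatter)), which means that hydrogen in place of methyl on a saturated chain carbon bound to an amine nitrogen and a saturated chain carbon makes no difference that can be read here, and among these three compounds the benzyl group alone stands apart. Nothing measured alongside these numbers explains the size of either step.

From the compounds shown here alone, whether the step follows the aromatic ring itself or simply the larger group stays open, and a longer chain such as butyl or a cyclohexylmethyl group at the same nitrogen would help separate the two. Going by these compounds, how an amine or a carboxylic acid at the end of this group would move the number also remains unknown.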